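Hydroxyethyl for butyl on the quinoxaline-free shared core

The compounds below may be only part of what the source reports. "The series", "measured", "known", "first", "only" and "open" are said of these compounds alone.

Measured compounds:
compound 1, `CCCCNc1nc2ccccc2nc1S(C)(=O)=O`: 12600 nM
compound 2, `CCCCNc1nc2cc(OC)ccc2nc1S(C)(=O)=O`: > 100000 nM

In an ADME assay on HepG2 cells (Homo sapiens) for cytotoxicity, read by CellTiter-Glo, with a stated time of 48 h (a higher number here means that more compound is tolerated, a lower number that less compound is tolerated), compound 1 gives 12600 nM. For compound 2 only a limit is known, > 100000 nM, so its true value is not pinned down. The step of an at least 7.9-fold higher number from compound 1 to compound 2 (0.89 log units; beyond the scatter) is therefore itself only a lower bound; see (the limit of > 100000 nM in this assay, at which 1 of the 2 values shown sits).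

Compound 3, `COc1ccc2nc(S(C)(=O)=O)c(NCCO)nc2c1`, is not yet measured. It differs from compound 2 by hydroxy in place of ethyl on a saturated chain carbon, two bonds along the chain from a nitrogen on an aromatic ring. Among the compounds with values here, no measured step changes this part of the molecule: the one step in hand, from compound 1 to compound 2, alters the aromatic carbon and leaves the butylamino chain untouched, so it gives no direct guide to the size or direction of the change to the chain. What remains is the standing of compound 2 at the limit of this assay.

Expectation for compound 3: the number is expected to stay close to the limit of compound 2, with the estimated step of a number no higher from compound 2 to compound 3 (the limit leaves the size open) amounting to no change beyond the scatter. Compound 3 is estimated at 100000 nM, within 30000 nM to 300000 nM.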

Compound 3, half-maximal cytotoxic concentration: > 100000 nM
Compound 3 gave a limit, no number (the forecaster's own chance of this, stated with the estimate: 60%); the middle value sits exactly at the limit.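

In this assay compound 3 gives > 100000 nM, which is a limit and not a number. Within the data shown here, compound 2 also stands at a limit, so no step between compound 2 and compound 3 can be read: the limit of > 100000 nM in this assay, at which 2 of the 3 values shown sit. Left open are the true values of compound 2 and compound 3, and with them whether butylamino to (2-hydroxyethyl)amino changes the number at all.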